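The source may hold more compounds than are shown below. What is called first, only, known or untested is meant among the compounds shown, and "the series" means these compounds.

Three compounds have numbers in a functional assay on L1210 cells (Mus musculus), with a stated time of 12 days; on this read-out higher numbers stand for higher potency (the scale is a negative logarithm) and lower numbers for lower potency:

Compound 1, `CC(C)C1=C(N2CC2)C(=O)C(C(C)C)=C(N2CC2)C1=O`, gives 4.59.
Compound 2, `CCC(COC(N)=O)C1=C(N2CC2)C(=O)C(C)=C(N2CC2)C1=O`, gives 5.66.
Compound 3, `CC1=C(N2CC2)C(=O)C(C2CCCCC2)=C(N2CC2)C1=O`, gives 5.39.

Compound 3 holds the second highest of the three numbers. Its nearest neighbour is compound 2, whose number lies within the usual scatter of that of compound 3, so no order can be read between the two; compound 1 is furthest away, beyond the scatter on the low side. Compound 4, `CC1=C(N2CC2)C(=O)C(CCCOC(N)=O)=C(N2CC2)C1=O`, has not yet been measured. It differs from compound 3 in one place: a group of 7 heavy atoms (4 carbon, 1 nitrogen, 2 oxygen; no ring) in place of a group of 6 heavy atoms (6 carbon; one six-membered non-aromatic ring of carbon only), on a double-bonded ring carbon. Within the data shown here, no step between two measured compounds that differ in one place is available, so the likely size of this change has to be judged from the three numbers alone. Among the measured compounds shown here, of the three measured compounds, the one closest to compound 4 in its side chain is compound 2, and compound 2 gives 5.66, a number within the scatter of compound 3. On that basis the expected step is small, a number 0.21 log units higher from compound 3 to compound 4 (within the scatter), not beyond the scatter in either direction. Compound 4 is therefore estimated to give 5.6 in this assay, with a range from 5.1 to 6.1.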

Compound 4, logarithm of the reciprocal of the active concentration, log(1/C): 5.93
For compound 4 the middle estimate is 0.33 log units below the measured one; measured number inside the range.
By their numbers in this assay, from the lowest: compound 1; then compounds 3, 2 and 4 (each within the scatter of the next, the first and the last beyond it).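

Among these compounds, at this position on a double-bonded ring carbon, this assay gives the one step available between two compounds that differ in one place: a number 0.54 log units higher from compound 3 to compound 4 (beyond the scatter). It shows that the cyclohexyl group, with its six-membered ring of carbon only, can give way to a ring-free group bearing a hydrogen-bond donor and two hydrogen-bond acceptors without any loss of potency, and that this exchange raises the number by more than the usual scatter. Nothing measured on these compounds accounts for the rise.

This single step changes the ring, the chain and the donor and acceptor counts together, so it cannot say which of them matters. From the compounds shown here alone, a plain butyl chain or a chain ending in a carboxylic acid at this position would help to separate those parts, and the effect of either remains open.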